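Benzyl Replacing Fluorophenyl on a Piperazine-Bearing Dithiocarbamate

This account rests on a few compounds, and the source may have more. Where it says the series, first, only, none or still open, it means among the compounds named here.

Measured so far:
compound 1, `Nc1ccccc1NC(=O)c1ccc(CSC(=S)N2CCN(C(c3ccccc3)c3ccccc3)CC2)cc1`: 8.4%
compound 2, `Nc1ccccc1NC(=O)c1ccc(CSC(=S)N2CCN(c3ccccc3F)CC2)cc1`: 79.5%

Of the compounds shown here, two have been measured in a functional assay on A-375 cells (Homo sapiens) for antiproliferative activity, read by CCK-8 assay, with a stated time of 72 h, tested at 8 uM; a higher number here means a stronger effect of the compound at the concentration tested, a lower number a weaker effect. Compound 1, which carries a diphenylmethyl group on the ring nitrogen, gives 8.4%. Compound 2, with a 2-fluorophenyl group in the same place, gives 79.5%. Compound 2 therefore stands highest of the two numbers, and its nearest neighbour, compound 1, lies far lower, a gap well beyond the usual scatter of this assay.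

The next compound, compound 3, `Nc1ccccc1NC(=O)c1ccc(CSC(=S)N2CCN(Cc3ccccc3)CC2)cc1`, has not yet been measured. It differs from compound 2 in one place: benzyl in place of 2-fluorophenyl on an amine nitrogen in a ring

With only two measured points, and no step between compounds differing in one place, the expectation rests on the pair shown. Compound 3 is expected to fall between the two measured values, closer to compound 1, so that the estimated step of a number 44.5 percentage points lower from compound 2 to compound 3 (beyond the scatter) is a decrease beyond the scatter. For compound 3 the estimate in this assay is 35%, with a range from 10% to 70%.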

Compound 3, a percentage reported as inhibition, at one concentration (the size of the read-out at that concentration, not a potency): 29.3%
Estimate against measurement, compound 3: 5.7 percentage points above; low and high end bracket the measured number.
By their numbers in this assay, from the lowest: compound 1; then compound 3; then compound 2.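

In this assay, benzyl in place of 2-fluorophenyl on the amine nitrogen in the ring gives a number 50.2 percentage points lower from compound 2 to compound 3 (beyond the scatter), although both groups have the same count of heavy atoms and each holds one six-membered aromatic ring of carbon only, so the read-out at this position depends on more than the size of the group by that count. Hydrogen in place of phenyl on the saturated chain carbon bound to that nitrogen gives a number 20.9 percentage points higher from compound 1 to compound 3 (beyond the scatter), a modest step beside the large one, which shows that removing one of the two phenyl groups restores only part of the read-out. Nothing measured here gives a reason for either step.

The change from compound 2 to compound 3 removes a fluorine and adds a saturated carbon in one move, so the compounds shown leave open which of the two carries the step; a plain phenyl or a 2-fluorobenzyl group on the same nitrogen would separate them. Also open, as far as these compounds go, is how a small group such as methyl or acetyl on this nitrogen would read in this assay.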